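Swapping chloro for nitro on an acetylated compound

A few compounds are considered here, and "the series" means these few. Any claim that something is new, unique, unknown or untested is made for them only; others in the source may bear on it.

Compound 1 `Nc1ccc(-c2nc3ccccc3s2)cc1Cl` gives < 1 nM (a limit)
Compound 2 `CC(=O)Nc1ccc(-c2nc3ccccc3s2)cc1Cl` gives > 100 nM (a limit)
Compound 3 `CC(=O)N(C(C)=O)c1ccc(-c2nc3ccccc3s2)cc1Cl` gives > 1000 nM (a limit)

In a functional assay on MDA-MB-468 cells (Homo sapiens) for antiproliferative activity (a higher number here means a weaker inhibitor, a lower number a stronger inhibitor), compound 2 gives > 100 nM as a limit and not as a number. Its true value is therefore unknown, like those of the other two compounds. Compound 4 `CC(=O)Nc1ccc(-c2nc3ccccc3s2)cc1[N+](=O)[O-]` has nitro in place of chloro on an aromatic carbon, ortho to an acetamido group (nitro in place of chloro on an aromatic carbon). Within the data shown here, no measured step makes this swap. The nearest evidence concerns acetyl on the nitrogen, where two steps are large (an at least 100-fold higher number from compound 1 to compound 2 (2.00 log units; beyond the scatter); an at least 1000-fold higher number from compound 1 to compound 3 (3.00 log units; beyond the scatter)). A third step stays unreadable (a step that the two limits leave unreadable from compound 2 to compound 3). Compound 4 keeps the acetamido group, so it is expected to remain a weak inhibitor, without the strength of compound 1. The step is expected to be moderate and towards a higher number, and this is an uncertain estimate (a step that the limit leaves unreadable from compound 2 to compound 4). For compound 4 the estimate is 1000 nM (expected range 150 nM to 10000 nM) and the assay may report only a limit.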

Compound 4, half-maximal inhibitory concentration: > 1000 nM
Compound 4: a limit, no number; the forecaster's own chance of this, stated with the estimate: 70%; the middle value sits exactly at the limit.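

Compound 2 and compound 4 each carry only a limit and not a number, so the step between them, nitro in place of chloro, cannot be read. The compounds shown leave open whether chloro or nitro gives the stronger inhibitor when the acetamido group is present, and by how much.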